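The source may hold more compounds than are shown below. What is called first, only, known or untested is meant among the compounds shown, and "the series" means these compounds.

Measured in a functional assay on KB cells (Homo sapiens) for cytotoxicity; a lower number here means that less compound is needed, a higher number that more compound is needed for the effect:
- compound 1 `COC1=C(C)C(=O)/C(=C(O)/C=C/c2ccc(OC)cc2)C(=O)C1(C)C`: 2.9 ug/mL
- compound 2 `COC1=C(C)C(=O)/C(=C(O)/C=C/c2ccc(F)cc2)C(=O)C1(C)C`: 2.7 ug/mL

Compound 2 stands level with compound 1 within the scatter. Compound 3 `COC1=C(C)C(=O)/C(=C(O)/C=C/c2ccc(C)cc2)C(=O)C1(C)C` differs from compound 2 by methyl in place of fluoro on an aromatic carbon. For the measured compounds named here, the one measured step that bears on this is also a swap on an aromatic carbon, fluoro in place of methoxy. It was small, a 1.1-fold lower number from compound 1 to compound 2 (0.03 log units; within the scatter). Going by the values given here, no measured compound yet carries the methyl, so this is thin evidence, and no step beyond the scatter is expected. The estimated change is a 1.0-fold higher number from compound 2 to compound 3 (0.02 log units; within the scatter). For compound 3 the expected value is 2.8 ug/mL, with an estimated range of 1.5 ug/mL to 5.5 ug/mL.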

Compound 3, concentration for half-maximal effect: 1.9 ug/mL
Compound 3: the middle estimate sits 1.5-fold (0.17 log units) above what was measured, and the stated range covers the measured number.
By their numbers in this assay, from the lowest: compounds 3, 2 and 1 (each within the scatter of the next).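

Putting methyl on this aromatic carbon, para to a large group, gives a 1.4-fold lower number from compound 2 to compound 3 (0.15 log units; within the scatter) and a 1.5-fold lower number from compound 1 to compound 3 (0.18 log units; within the scatter). The three small groups seen here, methoxy, fluoro and methyl, therefore cannot be told apart by their numbers, so this position accepts all three so far. No supporting measurement is available to explain the small differences. Still open, as far as these compounds go, is whether an amine, a carboxylic acid or a longer chain at this position would shift the number beyond the scatter, and whether moving a group elsewhere on the ring would do so.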